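The source may report more compounds than this note shows. Statements on the series, on what has been measured and on what is new or still open speak of the compounds shown alone.

Measured so far:
compound 1 `CC(C)N1CCCC(n2cc(S(=O)(=O)C3=C(Cl)NC4SC=CN34)c3cccnc32)C1`, 1.7 nM;
compound 2 `CC(C)N1CCCC(n2cc(S(=O)(=O)c3cccc(F)c3)c3cccnc32)C1`, 3.4 nM.

In an assay on HeLa cells for displacement of a labelled ligand from 5-hydroxytryptamine receptor 6 (Homo sapiens) (a lower number here means a stronger inhibitor, a higher number a weaker inhibitor), compound 1 gives the lowest of the two numbers shown, and compound 2 sits within the scatter of it: a 2.0-fold higher number from compound 1 to compound 2 (0.30 log units; within the scatter). That step exchanges the group on the sulfonyl sulfur and leaves the rest of the shared core untouched.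

Compound 3 `CN1CCCC(n2cc(S(=O)(=O)C3=C(Cl)NC4SC=CN34)c3cccnc32)C1` differs from compound 1 in a different place: methyl in place of isopropyl on an amine nitrogen in a ring. Among the compounds with values here, no measured step touches this amine nitrogen, so nothing among the measured compounds speaks directly to the size or direction of this change. Within the data shown here, the only measured step, a 2.0-fold higher number from compound 1 to compound 2 (0.30 log units; within the scatter), bears on another part of the molecule and is itself within the scatter. On that basis the step from compound 1 to compound 3 is expected to be small, estimated as a 1.5-fold higher number from compound 1 to compound 3 (0.17 log units; within the scatter). Compound 3 is therefore expected to give about 2.5 nM in this assay, within a range from 0.8 nM to 8 nM.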

Compound 3, inhibition constant: 2 nM
Compound 3: middle estimate off by 1.3-fold (0.10 log units), on the high side, within the range that was stated.
By their numbers in this assay, from the lowest: compounds 1, 3 and 2 (each within the scatter of the next).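

In this assay the amine nitrogen in the ring now has a measured step of its own (a 1.2-fold higher number from compound 1 to compound 3 (0.07 log units; within the scatter)), which lies within the scatter. With the group on the sulfonyl sulfur held as in compound 1, the 1-isopropylpiperidin-3-yl and 1-methylpiperidin-3-yl groups therefore cannot be told apart, so this assay does not distinguish isopropyl from methyl on this nitrogen. No measurement is available that would explain this result.

On these data alone, it remains open whether a hydrogen on this nitrogen, or a larger group such as a longer chain or benzyl, would give a step beyond the scatter. As far as these compounds go, it is also open whether methyl in place of isopropyl would give a similar step with the group that compound 2 carries on the sulfonyl sulfur.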